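The source may report more compounds than this note shows. Statements on the series, on what has been measured and on what is new or still open speak of the compounds shown alone.

The compounds here share one core and differ in the acidic tail attached to it. Compound 1 `O=C(O)CC1CCCC1Cc1ccc(OCc2ccc3ccccc3n2)cc1` gives 100 nM in an assay on membranes from lung (Cavia porcellus) for binding affinity to cysteinyl leukotriene receptor (Homo sapiens); a higher number here means a weaker inhibitor, a lower number a stronger inhibitor. Compound 2 `CC(CCc1nnn[nH]1)Cc1ccc(OCc2ccc3ccccc3n2)cc1` gives 12 nM, and compound 3 `O=C(O)CC1(CCc2ccc(OCc3ccc4ccccc4n3)cc2)CCCC1` gives 51 nM. Among these three numbers compound 3 stands second highest: its value and that of compound 1 lie within the usual scatter of each other, while compound 2 sits clearly lower.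

Compound 4 `CC(CCc1ccc(OCc2ccc3ccccc3n2)cc1)Cc1nnn[nH]1` has not yet been measured. It differs from compound 3 in one place: 1-((1H-tetrazol-5-yl)methyl)ethyl in place of 1-(carboxymethyl)cyclopentyl on a saturated chain carbon, two bonds along the chain from an aromatic carbon.

Among the compounds with values here, one measured step bears on this. Going from compound 1 to compound 2 replaced a carboxymethyl-bearing cyclopentyl with a tetrazolyl-bearing chain, and this gave an 8.3-fold lower number from compound 1 to compound 2 (0.92 log units; beyond the scatter). The change from compound 3 to compound 4 is of the same kind, swapping a cyclopentyl carboxylic acid for a tetrazole on a short branched chain, and compound 4 is close in build to compound 2.

A lower number is therefore expected for compound 4, and the step of a 4.3-fold lower number from compound 3 to compound 4 (0.63 log units; beyond the scatter) is the estimate here. Compound 4 is estimated at 12 nM, with a likely range from 4 nM to 40 nM.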

Compound 4, inhibition constant: 25 nM
Compound 4: the middle estimate sits 2.1-fold (0.32 log units) below what was measured; low and high end bracket the measured number.
By their numbers in this assay, from the lowest: compound 2; then compound 4; then compounds 3 and 1 (each within the scatter of the next).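

In this assay there is now a second step towards a lower number on moving from an acid-bearing cyclopentyl tail to a tetrazole-bearing chain: a 2.0-fold lower number from compound 3 to compound 4 (0.31 log units; beyond the scatter) joins an 8.3-fold lower number from compound 1 to compound 2 (0.92 log units; beyond the scatter) as a change in the same direction, this time on a saturated chain carbon two bonds along the chain from an aromatic carbon. Compound 4 also gains over the other cyclopentyl acid, with a 4.0-fold lower number from compound 1 to compound 4 (0.60 log units; beyond the scatter) showing the gain across a change in the tail and its attachment. The two tetrazole compounds are not interchangeable, since a 2.1-fold higher number from compound 2 to compound 4 (0.32 log units; beyond the scatter) shows that the arrangement of the chain still counts once the tetrazole is present.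

Nothing available here explains these differences. Each acid-to-tetrazole step also removes the cyclopentyl ring, so the share of each change stays unresolved; a carboxylic acid on the branched chain of compound 4 or a tetrazole on the cyclopentyl ring would separate them, while an acyl sulfonamide or a longer chain leaves further questions open about the tail.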